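The compounds below may be only part of what the source reports. "The series", "measured", "known", "first", "only" and "open" are said of these compounds alone.

Measured compounds in an assay on HEK293 cells for agonist activity at transient receptor potential cation channel subfamily M member 8 (Homo sapiens), read by fluorescence and calcium flux, with a stated time of 15 min; on this read-out lower numbers stand for an effect already at smaller amounts and higher numbers for an effect only at larger amounts of compound:
compound 1, `Cc1ccc(OCC(=O)N(Cc2cccs2)C(C)(C)C)cc1`, gives 11000 nM
compound 2, `Cc1ccc(OCC(=O)N(O)Cc2cccs2)cc1`, gives 8000 nM
compound 3, `Cc1ccc(OCC(=O)N(Cc2cccs2)c2c[nH]nc2C)cc1`, gives 0.4 nM

Among these three numbers compound 3 stands lowest, and by a wide margin: the step of a 20000-fold lower number from compound 2 to compound 3 (4.30 log units; beyond the scatter) and the step of a 28000-fold lower number from compound 1 to compound 3 (4.44 log units; beyond the scatter) both run far beyond the scatter, while the step of a 1.4-fold lower number from compound 1 to compound 2 (0.14 log units; within the scatter) does not leave it. The three compounds share one core and differ only in the group carried on the amide-type nitrogen, and the two ring-free groups on that nitrogen, tert-butyl and hydroxy, give numbers of the same order.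

Compound 4, `Cc1ccc(OCC(=O)N(CCCO)Cc2cccs2)cc1`, is the next member of this series. Its change from compound 3 is 3-hydroxypropyl in place of 3-methyl-1H-pyrazol-4-yl on an amide-type nitrogen. The two steps that bear on it are those into compound 3, which exchanged a ring-free group for the 3-methyl-1H-pyrazol-4-yl group and brought very large drops; compound 4 runs the opposite way, putting another ring-free group, a chain of the counted size, back in that place. Compound 4 is therefore expected to show a large rise in this assay, estimated as a 20000-fold higher number from compound 3 to compound 4 (4.30 log units; beyond the scatter), landing it near compounds 1 and 2 rather than near compound 3. The estimate for compound 4 is 8000 nM, with a range from 1000 nM to 40000 nM.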

Compound 4, half-maximal effective concentration: 3000 nM
Beside the measured number, compound 4's estimate is 2.7-fold (0.43 log units) above it, and the stated range covers the measured number.
By their numbers in this assay, from the lowest: compound 3; then compound 4; then compounds 2 and 1 (each within the scatter of the next).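

In this assay, the exchange of the 3-methyl-1H-pyrazol-4-yl group for 3-hydroxypropyl brings a 7500-fold higher number from compound 3 to compound 4 (3.88 log units; beyond the scatter), although the group that leaves and the group that enters have the same counts of hydrogen-bond donors and acceptors, so those counts alone do not hold the low number at this amide-type nitrogen. The ring-free groups are also now seen to differ among themselves: the series shows a 2.7-fold lower number from compound 2 to compound 4 (0.43 log units; beyond the scatter) and a 3.7-fold lower number from compound 1 to compound 4 (0.56 log units; beyond the scatter), both modest but beyond the scatter, and both small beside the step out of compound 3. The data shown offer no evidence that explains these differences.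

The compounds shown leave open whether the low number of compound 3 belongs to a five-membered aromatic ring in general or to this particular group, a question that a phenyl ring or a pyrazol-4-yl ring without its methyl would address. They also leave open how a chain ending in an amine or a carboxylic acid, or a longer chain ending in hydroxy, would read on this nitrogen.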